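Ester prodrugs of the shared core

A few compounds are considered here, and "the series" means these few. Any claim that something is new, unique, unknown or untested is made for them only; others in the source may bear on it.

Measured compounds:
compound 1 `CC(C)C(=O)OCOC(=O)C1=C(S[C@@H]2CN[C@H](C(=O)Nc3cccc(C(=O)OCOC(=O)C(C)C)c3)C2)[C@H](C)[C@@H]2[C@@H]([C@@H](C)O)C(=O)N12` — 1%
compound 2 `CCOC(=O)c1cccc(NC(=O)[C@@H]2C[C@H](SC3=C(C(=O)O)N4C(=O)[C@H]([C@@H](C)O)[C@H]4[C@H]3C)CN2)c1` — "not determined" (no result reported)
compound 3 `Cc1oc(=O)oc1COC(=O)c1cccc(NC(=O)[C@@H]2C[C@H](SC3=C(C(=O)O)N4C(=O)[C@H]([C@@H](C)O)[C@H]4[C@H]3C)CN2)c1` — 0%

In an ADME assay on a cell-free system (plasma, Rattus norvegicus) for metabolic stability, read by LC-MS, with a stated time of 60 min, at 37 degrees C, tested at 50 uM (a higher number here means that more of the compound is left, a lower number that less of the compound is left), compound 1 gives 1%. In this assay compound 3 gives 0%. The two numbers lie within the scatter of each other, so neither compound can be set above the other; both leave almost none of the parent remaining. Compound 2 carries an ethyl ester on the same core, and in this assay compound 2 gives "not determined" (no result reported).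

Compound 4 `CC(C)C(=O)OCOC(=O)c1cccc(NC(=O)[C@@H]2C[C@H](SC3=C(C(=O)O)N4C(=O)[C@H]([C@@H](C)O)[C@H]4[C@H]3C)CN2)c1` is the next member to be measured. It differs from compound 3 at one place: a group of 6 heavy atoms (4 carbon, 2 oxygen; no ring) in place of a group of 7 heavy atoms (4 carbon, 3 oxygen; one five-membered aromatic ring with 2 hetero atoms), on a saturated chain carbon bound to an oxygen next to a carbonyl group. Among the compounds with values here, no step between measured compounds matches this change, so only what compound 1 and compound 3 show can guide the expectation. Compound 1 carries the same entering group twice and gives 1%. On that basis the step of a number 1 percentage points higher from compound 3 to compound 4 (within the scatter) is expected to stay within the scatter, with no direction to it. Compound 4 is therefore estimated at 1%, with a range from 0% to 8%.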

Compound 4, percent of the compound remaining in the plasma assay: 0%
Beside the measured number, compound 4's estimate is 1 percentage points above it, within the range that was stated.
By their numbers in the plasma assay, from the lowest: compounds 3, 4 and 1 (each within the scatter of the next).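

Replacing the ring-bearing group with (isopropylcarbonyl)oxy, on a saturated chain carbon bound to an oxygen next to a carbonyl group, gives in the plasma assay no change at the digits printed from compound 3 to compound 4 (within the scatter), and hydrogen in place of ((isopropylcarbonyl)oxy)methyl on an oxygen next to a carbonyl group gives a number 1 percentage points lower from compound 1 to compound 4 (within the scatter), so neither change separates these compounds in that read-out. In a physicochemical assay for metabolic stability, read by LC-MS, in phosphate buffer, with a stated time of 3 h, at pH 7.4, tested at 50 uM (on this read-out higher numbers stand for a more stable compound and lower numbers for a less stable compound), compound 3 gives > 95%, which is a limit of the assay. In the physicochemical assay compound 4 gives > 95%, also a limit, and the step from compound 3 cannot be read because of that limit: the limit of > 95% in the physicochemical assay, at which 2 of the 2 values shown sit.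

Open, as far as these compounds go, is whether an amide or a longer acyl chain at this place would leave more of the compound in the plasma assay. With all the numbers there lying within the scatter of each other, the compounds shown give no order among these esters.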